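From cyclohexyl to cycloheptyl on a shared core

The compounds below may be only part of what the source reports. "The series", "measured", "known", "first", "only" and "open" are said of these compounds alone.

Compound 1 `O=C1Nc2c(ccc(F)c2F)C1(c1ccc(O)cc1)c1ccc(F)cc1` gives 2.1 h
Compound 2 `O=C1Nc2c(ccc(F)c2F)C1(c1ccc(O)cc1)C1CCCCC1` gives 1.6 h

Both numbers come from an in vivo ADME assay on the whole organism for metabolic stability, with Mus musculus as the target, at a dose of 5 mg/kg by the intravenous route; on this read-out lower numbers stand for a shorter-lived compound and higher numbers for a longer-lived compound. Compound 2 stands level with compound 1, since the two values lie within the scatter of each other. Compound 3 `O=C1Nc2c(ccc(F)c2F)C1(c1ccc(O)cc1)C1CCCCCC1` has not yet been measured in this assay. Its difference from compound 2 is cycloheptyl in place of cyclohexyl on a saturated ring carbon, which puts cycloheptyl in place of cyclohexyl on a saturated ring carbon. Among the measured compounds shown here, only one measured step bears on that carbon, a 1.3-fold lower number from compound 1 to compound 2 (0.12 log units; within the scatter), with cyclohexyl in place of 4-fluorophenyl. That single step stayed within the scatter, so no change beyond the scatter is expected for the new ring size in this assay. The expected step is no change at the digits printed from compound 2 to compound 3 (within the scatter). For compound 3 the estimated value is 1.6 h, with an expected range from 0.9 h to 2.8 h.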

Compound 3, half-life: 1.3 h
Estimate against measurement, compound 3: 1.2-fold (0.09 log units) above; measured number inside the range.
By their numbers in this assay, from the lowest: compounds 3, 2 and 1 (each within the scatter of the next).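

In this assay cycloheptyl in place of cyclohexyl on this saturated ring carbon gives a 1.2-fold lower number from compound 2 to compound 3 (0.09 log units; within the scatter) and cycloheptyl in place of 4-fluorophenyl gives a 1.6-fold lower number from compound 1 to compound 3 (0.21 log units; within the scatter) so the three groups stand level on this read-out. Where the earlier pair spoke for one exchange only, the half-life now fails to separate a six-membered ring, a seven-membered ring and an aromatic ring at this carbon. Nothing available accounts for this flat result.

As far as these compounds go, whether it extends to a smaller ring such as cyclopropyl, or to a group that carries an amine, such as piperidinyl, remains open. The compounds shown also leave open how a change elsewhere on the shared core would read out in this assay on this same carbon series.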